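The source may report more compounds than this note shows. Statements on the series, on what has been measured and on what is new or still open speak of the compounds shown alone.

Compound 2 `Cc1ccc(NC(=O)N[C@H]2CC[C@H](Oc3ccc(F)cc3)CC2)cc1` is among the compounds tested in a functional assay on CRL2813 cells (Homo sapiens) for cytotoxicity, read by sulforhodamine B assay, with a stated time of 5 days; on this read-out higher numbers stand for weaker inhibition and lower numbers for stronger inhibition. In this assay compound 2 reaches only the limit > 20000 nM, so no number is known for it. Compound 1 `O=C(Nc1cccc(C(F)(F)F)c1)N[C@H]1CC[C@H](O)CC1` also stops at a limit, > 20000 nM. This matters since the limit of > 20000 nM in this assay, at which 2 of the 3 values shown sit, marks where most of the shown values sit. Compound 3 `O=C(Nc1cccc(C(F)(F)F)c1)N[C@H]1CC[C@H](Oc2cccc(C(F)(F)F)c2)CC1` gives 1300 nM. Among the measured compounds shown here, the one computed step, an at least 15-fold lower number from compound 1 to compound 3 (1.18 log units; beyond the scatter), changes the group on the oxygen of the saturated ring, not the amide-type nitrogen. Compound 4 `CSc1ccccc1NC(=O)N[C@H]1CC[C@H](Oc2ccc(F)cc2)CC1` differs from compound 2 by 2-(methylsulfanyl)phenyl in place of 4-methylphenyl on an amide-type nitrogen. For the measured compounds named here, no measured step alters that nitrogen's substituent, so no size can be read off for this change. Compound 4 is therefore expected to stay weak, estimated at 20000 nM with a range from 5000 nM to 60000 nM, an expected step of a number no higher from compound 2 to compound 4 (the limit leaves the size open).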

Compound 4, half-maximal inhibitory concentration: > 20000 nM
Compound 4: a limit, no number; the forecaster's own chance of this, stated with the estimate: 70%; the middle value lies on the limit itself.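

Among the compounds shown here, compound 2 and compound 4 both stop at a limit in this assay, not at a number, so no step between them can be read. As far as these compounds go, whether 2-(methylsulfanyl)phenyl in place of 4-methylphenyl on the amide-type nitrogen changes the read-out at all stays open.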